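Acrylic acid series: methoxy for chloro at the aryl ring

A few compounds are considered here, and "the series" means these few. Any claim that something is new, unique, unknown or untested is made for them only; others in the source may bear on it.

Three compounds of the shared core carry a measurement in a functional assay on DU-145 cells (Homo sapiens) for cytotoxicity, read by MTT assay, with a stated time of 72 h; a lower number here means a stronger inhibitor, a higher number a weaker inhibitor. Compound 1 `CC(=O)n1cc(/C=C(/C(=O)O)c2ccccc2)c2cc(OCc3ccccc3)ccc21` gives 26700 nM. Compound 2 `COc1ccc(/C(=C\c2c[nH]c3ccc(OCc4ccccc4)cc23)C(=O)O)cc1` gives 38100 nM. Compound 3 `CC(=O)n1cc(/C=C(/C(=O)O)c2ccc(Cl)cc2)c2cc(OCc3ccccc3)ccc21` gives 1130 nM, the lowest number of the three; its nearest neighbour is compound 1 and the furthest is compound 2, both well beyond the scatter. Among the measured compounds shown here, the only single-point step measured is a 24-fold lower number from compound 1 to compound 3 (1.37 log units; beyond the scatter), so the chloro on the aryl ring is the one change known to move this assay, and it moves it a great deal.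

Compound 4 `COc1ccc(/C(=C\c2cn(C(C)=O)c3ccc(OCc4ccccc4)cc23)C(=O)O)cc1` is the next compound. It differs from compound 3 as follows: methoxy in place of chloro on an aromatic carbon. For the measured compounds named here, no measured step covers methoxy against chloro, and no measured step covers methoxy against hydrogen on the acetylated core; compound 2 carries the methoxy but differs from compound 1 in two places, and their values lie within the scatter of each other. Going by the values given here, the bearing step is therefore the one from compound 1 to compound 3: taking the chloro away is expected to give back most of that gain, so a clearly higher number is expected for compound 4 in this assay, of about an 18-fold higher number from compound 3 to compound 4 (1.25 log units; beyond the scatter). Compound 4 is estimated at 20000 nM, with a range from 5000 nM to 60000 nM.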

Compound 4, half-maximal inhibitory concentration: 910 nM
Estimate against measurement, compound 4: 22-fold (1.34 log units) above; the whole stated range lies above it.
By their numbers in this assay, from the lowest: compounds 4 and 3 (each within the scatter of the next); then compounds 1 and 2 (each within the scatter of the next).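

In this assay, the change from 4-chlorophenyl to 4-methoxyphenyl shows no separation, with a 1.2-fold lower number from compound 3 to compound 4 (0.09 log units; within the scatter) as the step, so the low number at this position on the acetylated core is not tied to chloro alone. Methoxy on the same aromatic carbon, para to a large group, also carries a large step over hydrogen, with a 29-fold lower number from compound 1 to compound 4 (1.47 log units; beyond the scatter) as the reading, and on the compounds shown either substituent separates clearly from hydrogen, while the acetyl on the aromatic nitrogen matters as well, with a 42-fold lower number from compound 2 to compound 4 (1.62 log units; beyond the scatter) as the step for that single change. No measurement at hand gives a reason for any of these steps.

As far as these compounds go, only chloro and methoxy are compared with hydrogen at this carbon, so it remains open whether a nitrile, an amine or a longer alkoxy chain there would sit with compound 3 and compound 4 or with compound 1. Also open, from the compounds shown here alone, is whether a methyl ester in place of the carboxylic acid would keep these numbers on the acetylated core.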